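Trimethylpiperazine in place of methylpiperazine: efficacy expectation

The compounds below may be only part of what the source reports. "The series", "measured", "known", "first", "only" and "open" are said of these compounds alone.

Measured compounds:
compound 1 `COc1cc2c(cc1N1C[C@@H](C)N(C)[C@@H](C)C1)N(C(=O)Nc1cccc(C(F)(F)F)c1Cl)CC2`: 0
compound 2 `COc1cc2c(cc1N1CCN(C)CC1)N(C(=O)c1ccc(-c3cccc(C)n3)c3ccccc13)CC2`: 0.9

In an assay on isolated protein with 5-hydroxytryptamine receptor 1B (Homo sapiens) as the target (a lower number here means a smaller maximal response, a higher number a larger maximal response), compound 2 gives 0.9, the higher of the two numbers recorded so far, while compound 1 gives 0, a gap beyond the scatter. The two differ in more than one place, so no single step can be read from them. Compound 3 `COc1cc2c(cc1N1C[C@@H](C)N(C)[C@@H](C)C1)N(C(=O)c1ccc(-c3cccc(C)n3)c3ccccc13)CC2` changes compound 2 in one place: 3,4,5-trimethylpiperazin-1-yl in place of 4-methylpiperazin-1-yl on an aromatic carbon. Going by the values given here, no measured pair shows this change alone. A step a number 0.20 lower from compound 2 to compound 3 (beyond the scatter) is expected, mostly downward but with much uncertainty. Compound 3 is estimated at 0.7, within 0.2 to 1.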

Compound 3, intrinsic activity: the largest response reached, as a fraction of the reference agonist's: 0.3
Estimate against measurement, compound 3: 0.40 above; measured number inside the range.
By their numbers in this assay, from the lowest: compound 1; then compound 3; then compound 2.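

In this assay, 3,4,5-trimethylpiperazin-1-yl in place of 4-methylpiperazin-1-yl on this aromatic carbon gives a number 0.60 lower from compound 2 to compound 3 (beyond the scatter), so the maximal response is sensitive to substitution on the piperazine ring at this position. The response is reduced but not lost, as compound 3 gives 0.3. Nothing available here explains the drop.

The compounds shown leave open whether the added methyl groups or their defined stereocentres matter more. Also open, on these data alone, is how a morpholine ring, with oxygen in place of the methyl-bearing nitrogen, would behave at this position.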